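Compound 2 to compound 4: a substitution at the assay limit

A few compounds are considered here, and "the series" means these few. Any claim that something is new, unique, unknown or untested is made for them only; others in the source may bear on it.

In an ADME assay on BJ cells (Homo sapiens) for cytotoxicity, with a stated time of 72 h (a higher number here means that more compound is needed for the effect, a lower number that less compound is needed), compound 1 (`Cc1cc(NC(=O)Nc2ccc(C(C)(C)C)cc2)c2ccccc2n1`) gives 20000 nM. Compound 2 (`Cc1cc(NC(=O)Nc2ccccc2OC(F)(F)F)c2ccccc2n1`) reads > 25000 nM, which is a limit and not a number. Compound 3 (`Cc1cc(NC(=O)Nc2cccc([N+](=O)[O-])c2)c2ccccc2n1`) reads > 25000 nM, also a limit. Compound 2 therefore stands at the limit of > 25000 nM in this assay, at which 2 of the 3 values shown sit.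

Compound 4 (`Cc1cc(NC(=O)Nc2ccccc2C(C)(C)C)c2ccccc2n1`) differs from compound 2 by tert-butyl in place of trifluoromethoxy on an aromatic carbon. The change is tert-butyl in place of trifluoromethoxy on an aromatic carbon, ortho to a large group. Among the measured compounds shown here, no measured pair isolates this change. For the measured compounds named here, the only measured tert-butyl compound is compound 1 at 20000 nM, so a small shift towards less compound needed in this assay is expected, possibly none beyond the scatter. The expected change is an at least 1.1-fold lower number from compound 2 to compound 4 (0.05 log units; that floor lies within the scatter). Compound 4 is estimated at 22000 nM, with an expected range from 10000 nM to 40000 nM.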

Compound 4, half-maximal effective concentration: 22000 nM
Compound 4: middle estimate and measured number agree at the digits printed; the measured number falls inside the stated range.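

Among the compounds shown here, compound 2 holds only a limit in this assay, > 25000 nM, so compound 4 supplies the first actual number for a group on an aromatic carbon, ortho to a large group. With tert-butyl in place of trifluoromethoxy, the step reads an at least 1.1-fold lower number from compound 2 to compound 4 (0.05 log units; that floor lies within the scatter). Only this floor can be stated, because one end of the step is not a number: the limit of > 25000 nM in this assay, at which 2 of the 4 values shown sit.

On these data alone, the true size of the step remains open. So does the effect of an amine or a carboxylic acid on this aromatic carbon.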